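Working notes: acylamino to alkylamino on the aminopyrimidine series

The compounds below may be only part of what the source reports. "The series", "measured", "known", "first", "only" and "open" are said of these compounds alone.

Compound 1 `COc1ccc(-c2cnc(N)nc2-c2ccccc2)cc1OC` and compound 2 `Nc1ncc(-c2ccc(O)c(Cl)c2)c(-c2ccccc2)n1` share the core of compound 3 `CCCCC(=O)Nc1ncc(-c2cccc(Cl)c2)c(-c2ccccc2)n1`. In an assay on CHO cells for displacement of a labelled ligand from adenosine receptor A1 (Homo sapiens), read by scintillation counting, with a stated time of 1 h, tested at 1 uM (on this read-out higher numbers stand for more inhibition at the one concentration tested (going by the name of the read-out) and lower numbers for less inhibition), compound 1 gives > 80%, which is a limit of the assay and not a number. Compound 2 likewise reaches > 80% in this assay, again a limit. Among the measured compounds shown here, compound 3 is the only one with a number, at 52% in this assay; the other two sit at the limit of > 80% in this assay, at which 2 of the 3 values shown sit. Compound 4 `CC(C)CCNc1ncc(-c2cccc(Cl)c2)c(-c2ccccc2)n1` has not yet been measured. It differs from compound 3 by isopentyl in place of butylcarbonyl on a nitrogen on an aromatic ring. For the measured compounds named here, no measured pair covers this kind of change, so the expected step is a modest rise in this assay, of about a number 13 percentage points higher from compound 3 to compound 4 (beyond the scatter). Compound 4 is therefore expected to give roughly 65%, within 35% to 90%.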

Compound 4, a percentage reported as inhibition, at one concentration (the size of the read-out at that concentration, not a potency): 39%
Compound 4: middle estimate off by 26 percentage points, on the high side; low and high end bracket the measured number.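

In this assay, among the compounds shown here, the change on this nitrogen gives a number 13 percentage points lower from compound 3 to compound 4 (beyond the scatter) and so supplies the first reading for this position. Replacing the acyl group with an alkyl chain of similar size therefore does not raise the read-out for this pair. The series offers few numbers for setting this step in context: the limit of > 80% in this assay, at which 2 of the 4 values shown sit.

This single pair cannot separate the loss of the carbonyl from the change in chain shape. Also open, as far as these compounds go, is how a shorter alkyl chain, a benzyl group or a urea on this nitrogen would read.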